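Aromatic-Nitrogen Substituent: Propanoyl Exchanged for Methyl

The source may report more compounds than this note shows. Statements on the series, on what has been measured and on what is new or still open speak of the compounds shown alone.

In an assay on Sf9 cells for inhibition of inhibitor of nuclear factor kappa-B kinase subunit epsilon (Homo sapiens), read by ADP-Glo, with a stated time of 60 min (on this read-out lower numbers stand for stronger inhibition and higher numbers for weaker inhibition), compound 2 `CCC(=O)n1nc(C)c(-c2ccc(Cl)c(Cl)c2)c1N` gives only a limit, > 100000 nM. Compound 3 `CC(=O)n1nc(C)c(-c2cccc(Cl)c2)c1N` likewise gives a limit, > 100000 nM. Compound 1 `Cc1[nH]nc(N)c1-c1ccc2ccccc2c1` also gives a limit, > 100000 nM. Compound 2 thus stands among values that are all limits, at the limit of > 100000 nM in this assay, at which 3 of the 3 values shown sit, so no order among the three can be read. For the measured compounds named here, no step between measured compounds is available. Compound 4 `Cc1nn(C)c(N)c1-c1ccc(Cl)c(Cl)c1` differs from compound 2 by methyl in place of propanoyl on an aromatic nitrogen. Going by the values given here, no measured step bears on this change, so the expected shift is a number no higher from compound 2 to compound 4 (the limit leaves the size open), none beyond the usual scatter. For compound 4 the estimated value in this assay is 100000 nM, within 20000 nM to 300000 nM, and most likely again reported only as a limit.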

Compound 4, half-maximal inhibitory concentration: > 100000 nM
Compound 4: no number, only a limit; the forecaster's own chance of this, stated with the estimate: 75%; the middle value sits exactly at the limit.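

In this assay compound 4 gives > 100000 nM, a limit. For the compounds shown here, compound 2 gives > 100000 nM, also a limit, so no step from propanoyl to methyl can be read between compound 2 and compound 4. The compounds shown leave open whether exchanging these groups on the aromatic nitrogen shifts inhibition at all: the limit of > 100000 nM in this assay, at which 4 of the 4 values shown sit.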